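Isopropoxy in place of phenylsulfanyl on a shared core

The source may hold more compounds than are shown below. What is called first, only, known or untested is meant among the compounds shown, and "the series" means these compounds.

Measured compounds:
compound 1 `c1ccc(Sc2nn3cc(-c4cc5ccccc5o4)nc3s2)cc1` — "not determined" (no result reported)
compound 2 `COc1cc(OCc2cccc(OCc3ccccc3)c2)c2cc(-c3cn4nc(OC)sc4n3)oc2c1` — 8 nM

Compound 1 carries a phenylsulfanyl group on its fused core. In an assay for antagonist activity at proteinase-activated receptor 4 (Homo sapiens), with stated times of 5 min, 50 s and 15 min, in the presence of a further agent that is not named here (a lower number here means a stronger inhibitor, a higher number a weaker inhibitor), compound 1 has no result, and its standing is "not determined" (no result reported). Compound 2, which carries a methoxy group on the same kind of core and a more elaborate substituted ring system, gives 8 nM in this assay.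

Compound 3 `CC(C)Oc1nn2cc(-c3cc4ccccc4o3)nc2s1` differs from compound 1 by one change: isopropoxy in place of phenylsulfanyl on an aromatic carbon. Going by these compounds, because compound 1 stands at "not determined" (no result reported), the size and direction of the step to compound 3 in this assay cannot be read from its values; the step is unknown rather than within or beyond the scatter. Going by the values given here, the only anchor is compound 2 at 8 nM, which shares the core and a small alkoxy group but not the rest of the molecule. On that basis compound 3 is expected to give about 80 nM in this assay, with a range from 15 nM to 500 nM.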

Compound 3, half-maximal inhibitory concentration: > 30000 nM
Compound 3: only a limit was reported; the forecaster's own chance of this, stated with the estimate: 20%; middle value at least 370-fold (2.57 log units) from the limit.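

In this assay no step can be read between compound 1 and compound 3. For compound 3, > 30000 nM is a limit of the assay and not a number. The compounds shown leave open how phenylsulfanyl and isopropoxy compare on the shared core in this assay.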